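A few compounds are considered here, and "the series" means these few. Any claim that something is new, unique, unknown or untested is made for them only; others in the source may bear on it.

Measured compounds:

compound 1 `CC(=O)c1ccc(NC(=O)CN(C(=O)c2ccccc2)S(=O)(=O)c2ccc(C)cc2)cc1` — 18.1%
compound 2 `CCC(C)C(C(=O)Nc1ccc(C(C)=O)cc1)N(C(=O)c1ccccc1)S(=O)(=O)c1ccc(C)cc1` — 25.7%
compound 3 `CC(=O)c1ccc(NC(=O)CN(C(=O)c2ccccc2)S(=O)(=O)c2ccc([N+](=O)[O-])cc2)cc1` — 20.6%

In a functional assay for inhibition, read by spectrophotometry, with a stated time of 20 min, tested at 2 mg/mL (a lower number here means a weaker effect, a higher number a stronger effect of the compound at the concentration tested), compound 1 gives 18.1%, compound 2 gives 25.7% and compound 3 gives 20.6%. Compound 3 sits in the middle of the three numbers, but a number 2.5 percentage points higher from compound 1 to compound 3 (within the scatter), and the values of compound 3 and compound 2 also lie close together, so no order among the three can be claimed.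

Compound 4 `CC(=O)c1ccc(NC(=O)C(C(C)C)N(C(=O)c2ccccc2)S(=O)(=O)c2ccc([N+](=O)[O-])cc2)cc1` is yet to be measured in this assay. Compared with compound 3 it carries isopropyl in place of hydrogen on a saturated chain carbon bound to an amide-type nitrogen and a carbonyl carbon. Within the data shown here, one measured step bears on this: a larger alkyl group entered the same place when a number 7.6 percentage points higher from compound 1 to compound 2 (within the scatter). A similar but smaller group enters here, so a step of the same kind is expected, and a number 4.4 percentage points higher from compound 3 to compound 4 (within the scatter) is estimated to stay within the scatter. Compound 4 is therefore expected to give about 25% in this assay, with a range from 13% to 37%.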

Compound 4, a percentage reported as inhibition, at one concentration (the size of the read-out at that concentration, not a potency): 29.8%
Estimate against measurement, compound 4: 4.8 percentage points below; measured number inside the range.
By their numbers in this assay, from the lowest: compounds 1, 3, 2 and 4 (each within the scatter of the next, the first and the last beyond it).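

In this assay, the new compound gives a second reading of a branched alkyl group on the saturated chain carbon bound to an amide-type nitrogen and a carbonyl carbon, this time with nitro rather than methyl on the aromatic carbon. Isopropyl in place of hydrogen gives a number 9.2 percentage points higher from compound 3 to compound 4 (within the scatter) and sits alongside the sec-butyl step, a number 7.6 percentage points higher from compound 1 to compound 2 (within the scatter) so both steps have the same sign, though neither is beyond the scatter on its own. Nothing measured here accounts for these numbers.

Isopropyl and sec-butyl stand on cores that differ at the aromatic carbon, so the compounds shown cannot separate the two groups. On these data alone, it also remains open how a longer chain, a benzyl group, an amine or a carboxylic acid at this carbon would read.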